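The source may hold more compounds than are shown below. What is called first, only, known or untested is meant among the compounds shown, and "the series" means these compounds.

Measured so far:
compound 1 `[N-]=[N+]=NC[C@H]1NC[C@@H](O)[C@H]1O` — 43%
compound 2 `O[C@H]1[C@@H](O)CN[C@@H]1Cn1cc(-c2ccccc2)nn1` — 60%

In an assay on isolated protein for inhibition of alpha-mannosidase (Canavalia ensiformis), with stated times of 5 min and 20 min, tested at 1 mM (on this read-out lower numbers stand for less inhibition and higher numbers for more inhibition at the one concentration tested (going by the name of the read-out)), compound 1 gives 43%, the lower of the two numbers; compound 2, with 60%, sits higher by a gap beyond the usual scatter. Within the data shown here, no single-change step between measured compounds exists here, so the direction of a change of configuration is not known. Compound 3 `[N-]=[N+]=NC[C@@H]1NC[C@@H](O)[C@H]1O` differs from compound 1 as follows: the two compounds have the same atoms and bonds; at least one stereo element is drawn with a configuration in one of them and without one in the other: 1 of 4 stereo elements differ; a stereocentre at a saturated ring carbon is drawn R in compound 1 and S in compound 3. The step from compound 1 to compound 3 in this assay is expected to be a number 3 percentage points lower from compound 1 to compound 3 (within the scatter), of uncertain sign. Compound 3 is estimated at 40%, within 8% to 72%.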

Compound 3, a percentage reported as inhibition, at one concentration (the size of the read-out at that concentration, not a potency): 71%
Compound 3: the middle estimate sits 31 percentage points below what was measured; measured number inside the range.
By their numbers in this assay, from the lowest: compound 1; then compound 2; then compound 3.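

In this assay, changing this one stereocentre at a saturated ring carbon, with atoms and bonds the same, gives a number 28 percentage points higher from compound 1 to compound 3 (beyond the scatter) and so shows that configuration alone can move the number at this position, something compound 1 and compound 2 could not show. One caveat attaches to this reading: the fact that one of compounds 1 and 3 is drawn with a defined configuration and the other without, at the place where they differ.

Still open, from the compounds shown here alone, is whether the same change of configuration would act alike on compound 2. Also open, going by these compounds, is what a hydroxymethyl group would give at this ring carbon in either configuration.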